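The source may report more compounds than this note shows. Statements on the series, on what has been measured and on what is new or still open speak of the compounds shown alone.

In a functional assay on MCF7 cells (Homo sapiens) for cytotoxicity, read by MTT assay, with a stated time of 72 h (a lower number here means a stronger inhibitor, a higher number a weaker inhibitor), the measured compounds are:
Compound 1, `Cc1c(C(=O)Nc2ccc(Oc3ccnc4[nH]ccc34)c(F)c2)nnn1-c1ccccc1`: 350 nM
Compound 2, `Cc1c(C(=O)Nc2ccc(Oc3ccnc4[nH]ccc34)c(F)c2)nnn1-c1ccccc1F`: 420 nM
Compound 3, `Cc1c(C(=O)Nc2ccc(Oc3ccnc4[nH]ccc34)c(F)c2)nnn1-c1ccc(F)c(F)c1`: 820 nM

Compound 2 lies close to compound 1, the gap being a 1.2-fold higher number from compound 1 to compound 2 (0.08 log units; within the scatter), and further from compound 3, the step being a 2.0-fold higher number from compound 2 to compound 3 (0.29 log units; within the scatter). Compound 4, `Cc1c(C(=O)Nc2ccc(Oc3ccnc4[nH]ccc34)cc2)nnn1-c1ccccc1F`, differs from compound 2 by hydrogen in place of fluoro on an aromatic carbon. Within the data shown here, no measured step touches that ring; the nearest precedents are the fluoro changes on the other aromatic ring, a 1.2-fold higher number from compound 1 to compound 2 (0.08 log units; within the scatter) and a 2.0-fold higher number from compound 2 to compound 3 (0.29 log units; within the scatter), one within the scatter and one at its edge. The removal of a single fluoro is therefore expected to give no step beyond the scatter in this assay. Compound 4 is estimated at 420 nM, with a range from 200 nM to 900 nM. This expectation corresponds to a step of no change at the digits printed from compound 2 to compound 4 (within the scatter).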

Compound 4, half-maximal inhibitory concentration: 280 nM
Beside the measured number, compound 4's estimate is 1.5-fold (0.18 log units) above it, within the range that was stated.
By their numbers in this assay, from the lowest: compounds 4, 1, 2 and 3 (each within the scatter of the next, the first and the last beyond it).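

At this aromatic carbon, the first step measured at this position, hydrogen in place of fluoro, gives a 1.5-fold lower number from compound 2 to compound 4 (0.18 log units; within the scatter) in this assay. With 2-fluorophenyl on the aromatic nitrogen, this position therefore tolerates the loss of the fluoro without a step beyond the scatter. No supporting measurement bears on this result.

The compounds shown leave open whether the same holds with phenyl or 3,4-difluorophenyl on that nitrogen. They also leave open how a chloro, a methoxy or an amine at this aromatic carbon would read in this assay.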